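This account rests on a few compounds, and the source may have more. Where it says the series, first, only, none or still open, it means among the compounds named here.

Going by the values given here, in a functional assay on MGC-803 cells (Homo sapiens) for antiproliferative activity, read by MTT assay, with a stated time of 72 h (a higher number here means a weaker inhibitor, a lower number a stronger inhibitor), compound 2 `CCCSc1nc(N/N=C/c2c(O)ccc3ccccc23)c2nnn(Cc3ccccc3)c2n1` gives 3710 nM, the only plain number in the set. Compound 1 `CCCSc1nc(N/N=C/c2ccc(Cl)cc2)c2nnn(Cc3ccccc3)c2n1` sits at the limit of > 64000 nM in this assay, at which 1 of the 2 values shown sits, in this assay, so for compound 1 the result > 64000 nM is a limit rather than a number. Among the compounds with values here, the one measured step, an at least 17-fold lower number from compound 1 to compound 2 (1.23 log units; beyond the scatter), is the change from 4-chlorophenyl to 2-hydroxynaphthalen-1-yl on a carbon with a double bond to nitrogen. Compound 3 `CCCSc1nc(N/N=C/c2ccc([N+](=O)[O-])cc2)c2nnn(Cc3ccccc3)c2n1` is not yet measured; it differs from compound 2 by 4-nitrophenyl in place of 2-hydroxynaphthalen-1-yl on a carbon with a double bond to nitrogen. This moves back toward compound 1: 4-nitrophenyl, like 4-chlorophenyl, is one six-membered aromatic ring of carbon only. Compound 3 is therefore expected to give a clearly higher number in this assay, with the expected step being an 8.1-fold higher number from compound 2 to compound 3 (0.91 log units; beyond the scatter). The estimate for compound 3 is 30000 nM, between 8000 nM and 64000 nM, with a real chance that only a limit is reported.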

Compound 3, half-maximal inhibitory concentration: 10100 nM
The estimate for compound 3 lay 3.0-fold (0.47 log units) above the measured number; the range from low to high includes it.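

In this assay, going by these compounds alone, a single six-membered aromatic ring at this place can give a measurable result: on the carbon with a double bond to nitrogen, 4-nitrophenyl gives an at least 6.3-fold lower number from compound 1 to compound 3 (0.80 log units; beyond the scatter), and the only change is nitro in place of chloro on an aromatic carbon. The result for compound 1 remains a limit, not a number: the limit of > 64000 nM in this assay, at which 1 of the 3 values shown sits. The group on the single ring therefore matters, and the two-ring 2-hydroxynaphthalen-1-yl keeps the lowest number, with a 2.7-fold higher number from compound 2 to compound 3 (0.43 log units; beyond the scatter).

The compounds shown leave open whether the hydroxyl or the second ring of 2-hydroxynaphthalen-1-yl accounts for that remaining gap, a question that plain naphthalen-1-yl and 2-hydroxyphenyl would separate. From the compounds shown here alone, how an amine or a methoxy group on the single ring would compare also stays open.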